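A few compounds are considered here, and "the series" means these few. Any claim that something is new, unique, unknown or untested is made for them only; others in the source may bear on it.

Working notes on the series.

Of the compounds shown here, two of the shared core have been measured in an assay on membranes from HeLa cells for displacement of a labelled ligand from adenosine receptor A3 (Homo sapiens), read by scintillation counting, with a stated time of 180 min, tested at 1 uM; a higher number here means more inhibition at the concentration tested (going by the name of the read-out), a lower number less inhibition. Compound 1 `COC(=O)C1=C(C)NC(=O)NC1c1ccoc1` gives 2%. Compound 2 `CC1=C(C(=O)OC2CCCC2)C(c2ccco2)NC(=O)N1` gives 14%, the higher of the two numbers; the gap to compound 1 lies beyond the usual scatter. Compound 1 and compound 2 differ in more than one place, so no single step can be read between them.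

Compound 3 `CC1=C(C(=O)OC2CCCC2)C(c2ccoc2)NC(=O)N1` has not been measured. It differs from compound 2 in one place: furan-3-yl in place of furan-2-yl on a saturated ring carbon. Nothing in the measured pair isolates this change, so the size of the step in this assay is uncertain. Both measured numbers are low, and a move of the oxygen within the five-membered ring is expected to shift the inhibition only modestly, if at all, with the direction open.

For compound 3 the expected read-out in this assay is estimated at 9%, within a range from 0% to 22%. The step this implies, a number 5 percentage points lower from compound 2 to compound 3 (within the scatter), is expected to lie within the scatter of repeated measurements, leaning slightly downward.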

Compound 3, a percentage reported as inhibition, at one concentration (the size of the read-out at that concentration, not a potency): 1%
The estimate for compound 3 lay 8 percentage points above the measured number; the range from low to high includes it.
By their numbers in this assay, from the lowest: compounds 3 and 1 (each within the scatter of the next); then compound 2.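

In this assay, for the compounds shown here, furan-3-yl in place of furan-2-yl on a saturated ring carbon gives a number 13 percentage points lower from compound 2 to compound 3 (beyond the scatter), the first single-place step. It shows that the point of attachment of the furan is read by this assay, even though the two groups carry the same atoms and the same counts. With furan-3-yl held constant, cyclopentyl in place of methyl on an oxygen next to a carbonyl group gives a number 1 percentage points lower from compound 1 to compound 3 (within the scatter), so this exchange separates nothing in the presence of that furan, and the small signal of compound 2 appears only with cyclopentyl and furan-2-yl together. No measurement at hand explains either step.

As far as these compounds go, whether furan-2-yl would stand out in the same way with methyl on that oxygen remains open, so the two places cannot yet be judged independently of each other. Also open, from the compounds shown here alone, is whether a phenyl or thiophene ring on the saturated ring carbon, or a longer chain such as n-butyl on the oxygen, would carry the inhibition clearly beyond these low numbers.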